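The compounds below may be only part of what the source reports. "The series", "measured", "known", "first", "only" and "open" are said of these compounds alone.

Within the data shown here, in a functional assay on A549 cells (Homo sapiens) for cytotoxicity, read by MTT assay, with a stated time of 72 h (a lower number here means a stronger inhibitor, a higher number a weaker inhibitor), two compounds with a shared core have numbers so far. Compound 1 (`COc1ccc(NC(=O)CN2CCN(c3nnc(Cc4ccncc4)c4ccccc34)CC2)cc1OC`) gives 26500 nM, and compound 2 (`Cc1ccc(NC(=O)CN2CCN(c3nnc(Cc4ccncc4)c4ccccc34)CC2)c(C)c1`) gives 45000 nM. Among the measured compounds shown here, the one measured step, a 1.7-fold higher number from compound 1 to compound 2 (0.23 log units; within the scatter), lies within the scatter, so compound 2 stands level with compound 1 and the two cannot be ordered. Compound 3 (`O=C(CN1CCN(c2nnc(Cc3ccncc3)c3ccccc23)CC1)Nc1cccc(Br)c1`) keeps the core and carries 3-bromophenyl in place of 2,4-dimethylphenyl on an amide-type nitrogen. For the measured compounds named here, the measured step changed the group at this same place, so it is the only guide, although no measured compound carries bromine. On that slender evidence, no change beyond the scatter is expected in this assay. The expected size is a 1.3-fold lower number from compound 2 to compound 3 (0.11 log units; within the scatter). Compound 3 is estimated at 35000 nM, with an expected range from 14000 nM to 85000 nM.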

Compound 3, half-maximal inhibitory concentration: 1530 nM
Compound 3: the middle estimate sits 23-fold (1.36 log units) above what was measured, and the stated range ends above it.
By their numbers in this assay, from the lowest: compound 3; then compounds 1 and 2 (each within the scatter of the next).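

In this assay the group on the amide-type nitrogen proves able to move the number strongly: 3-bromophenyl brings a 29-fold lower number from compound 2 to compound 3 (1.47 log units; beyond the scatter) and also a 17-fold lower number from compound 1 to compound 3 (1.24 log units; beyond the scatter), whereas the two earlier groups could not be told apart. Both 3-bromophenyl and 2,4-dimethylphenyl are one six-membered aromatic ring of carbon only, with 0 hydrogen-bond donors and 0 hydrogen-bond acceptors, so this large step occurs with those counts unchanged. Nothing at hand accounts for the size of the step.

The compounds shown do not separate the entry of the bromine from the loss of the two methyl groups or from the different substitution pattern on the ring. They also leave open how an unsubstituted phenyl, or a chlorine or iodine atom in place of the bromine, would read in this assay.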